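The compounds below may be only part of what the source reports. "The series", "measured", "known", "first", "only" and "open" are said of these compounds alone.

Compound 1 `COc1ccc(-c2ccc(Cl)cc2)c(COc2ccc(-c3nc4cc(C(=O)O)ccc4n3C3CCCCC3)cc2)c1`: 24000 nM.
Compound 2 `CN(C)S(=O)(=O)c1ccc(-c2ccc(Cl)cc2)c(COc2ccc(-c3nc4cc(C(=O)O)ccc4n3C3CCCCC3)cc2)c1`: 26000 nM.
Compound 3 `O=C(O)c1ccc(-c2ccc(Cl)cc2)c(COc2ccc(-c3nc4cc(C(=O)O)ccc4n3C3CCCCC3)cc2)c1`: > 50000 nM, a limit.

These values come from a functional assay on Huh-5-2 cells (Homo sapiens), read by MTT assay; on this read-out higher numbers stand for lower toxicity in this test and lower numbers for higher toxicity in this test. Compound 3 has no number, only (the limit of > 50000 nM in this assay, at which 1 of the 3 values shown sits). Compound 4 `CN(C)C(=O)c1ccc(-c2ccc(Cl)cc2)c(COc2ccc(-c3nc4cc(C(=O)O)ccc4n3C3CCCCC3)cc2)c1` differs from it by dimethylamino in place of hydroxy on a carbonyl carbon, or carboxy to dimethylcarbamoyl. Going by the values given here, three measured steps bear on this change. The first is an at least 2.0-fold higher number from compound 1 to compound 3 (0.31 log units; beyond the scatter). The second is an at least 1.9-fold higher number from compound 2 to compound 3 (0.28 log units; that floor lies within the scatter). The third, a 1.1-fold higher number from compound 1 to compound 2 (0.03 log units; within the scatter), shows two different non-carboxy groups giving values within the scatter of each other. Compound 4 also lacks the carboxy at this place, so it is expected to sit near compound 1 and compound 2. The expected change is an at least 1.6-fold lower number from compound 3 to compound 4 (0.22 log units; that floor lies within the scatter), a modest fall. For compound 4 the estimated value is 30000 nM, with an expected range from 15000 nM to 50000 nM.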

Compound 4, half-maximal cytotoxic concentration: 28000 nM
The estimate for compound 4 lay 1.1-fold (0.03 log units) above the measured number; low and high end bracket the measured number.
By their numbers in this assay, from the lowest: compounds 1, 2 and 4 (each within the scatter of the next). At a limit, above all of these: compound 3.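

In this assay, dimethylcarbamoyl on this aromatic carbon joins the two other non-carboxy groups, as a 1.1-fold higher number from compound 2 to compound 4 (0.03 log units; within the scatter) and a 1.2-fold higher number from compound 1 to compound 4 (0.07 log units; within the scatter) show. It keeps the carbonyl of the carboxy group, yet replacing hydroxy with dimethylamino on that carbonyl carbon gives an at least 1.7-fold lower number from compound 3 to compound 4 (0.25 log units; that floor lies within the scatter), so this step alone does not establish a fall. Compound 3 stands at a limit, not a number: the limit of > 50000 nM in this assay, at which 1 of the 4 values shown sits.

From the compounds shown here alone, whether a sulfonic acid or a primary amide here would sit with compound 1, compound 2 and compound 4, or with compound 3, stays open.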